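Swapping the aryl group on a growth-inhibiting hydrazone

This account rests on a few compounds, and the source may have more. Where it says the series, first, only, none or still open, it means among the compounds named here.

Measured in a functional assay on OVCAR-3 cells (Homo sapiens) for inhibition, read by sulforhodamine B assay, with a stated time of 48 h; a higher number here means a weaker inhibitor of growth, a lower number a stronger inhibitor of growth:
Compound 1 `O=C(Cc1csc2nc(-c3ccc(Br)cc3)cn12)N/N=C/c1ccccc1O`: 15100 nM
Compound 2 `COc1cccc(OC)c1/C=N/NC(=O)Cc1csc2nc(-c3ccc(Br)cc3)cn12`: 58900 nM

Compound 2 has the higher number of the two, so it is the weaker growth inhibitor of this pair. Compound 3 `O=C(Cc1csc2nc(-c3ccc(Br)cc3)cn12)N/N=C/c1ccc(Cl)cc1Cl` keeps the shared core and differs by 2,4-dichlorophenyl in place of 2,6-dimethoxyphenyl on a carbon with a double bond to nitrogen. Among the measured compounds shown here, only one measured step changes the group at this carbon: a 3.9-fold higher number from compound 1 to compound 2 (0.59 log units; beyond the scatter), a modest move. A step of similar or smaller size is therefore expected in this assay, probably towards a lower number, though the direction is uncertain. The expected change is a 2.1-fold lower number from compound 2 to compound 3 (0.32 log units; beyond the scatter). The estimated value for compound 3 is 28000 nM, with an expected range of 9000 nM to 85000 nM.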

Compound 3, concentration for total growth inhibition: > 100000 nM
Compound 3 gave a limit, no number; the forecaster's own chance of this, stated with the estimate: 15%; middle value at least 3.5-fold (0.55 log units) from the limit.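

In this assay compound 3 gives a limit and not a number: the limit of > 100000 nM in this assay, at which 1 of the 3 values shown sits. With 2,4-dichlorophenyl on this carbon, the data show an at least 6.6-fold higher number from compound 1 to compound 3 (0.82 log units; beyond the scatter), while an at least 1.6-fold higher number from compound 2 to compound 3 (0.22 log units; that floor lies within the scatter) has a floor that cannot separate that pair. Compound 1, with 2-hydroxyphenyl, remains the strongest growth inhibitor of the three.

The compounds shown leave open how far compound 3 really lies from compound 2. They also leave open how an unsubstituted phenyl, or a phenyl carrying an amine or a carboxylic acid, would read on this carbon.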